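The source may report more compounds than this note shows. Statements on the series, on what has been measured and on what is new or still open speak of the compounds shown alone.

Measured compounds and their values:

- Compound 1, `COCC#Cc1cc(C(O)(C(F)(F)F)C(F)(F)F)cnc1N1CCN(S(=O)(=O)c2ccc(N)nc2)CC1`: 15 mL.min-1.g-1
- Compound 2, `Cn1cc(-c2cc(C(O)(C(F)(F)F)C(F)(F)F)cnc2N2CCN(S(=O)(=O)c3ccc(N)nc3)CC2)cn1`: 19 mL.min-1.g-1
- Compound 3, `Nc1ccc(S(=O)(=O)N2CCN(c3ncc(C(O)(C(F)(F)F)C(F)(F)F)cc3-c3cccnc3)CC2)cn1`: 17 mL.min-1.g-1

All three values come from an ADME assay (liver) for metabolic stability, with Liver microsome (Homo sapiens) as the target, using microsomes and NADPH, with a stated time of 30 min, tested at 1 uM; a lower number here means slower removal, a higher number faster removal of the compound. Compound 3 gives a number that sits among the other two: against compound 2 the difference is a 1.1-fold lower number from compound 2 to compound 3 (0.05 log units; within the scatter), and against compound 1 it is a 1.1-fold higher number from compound 1 to compound 3 (0.05 log units; within the scatter). Neither of these steps, nor the step of a 1.3-fold higher number from compound 1 to compound 2 (0.10 log units; within the scatter), reaches beyond the scatter, so the three groups tried so far at this position have left the read-out essentially unchanged.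

Compound 4, `Nc1ccc(S(=O)(=O)N2CCN(c3ncc(C(O)(C(F)(F)F)C(F)(F)F)cc3-c3cccc4[nH]ncc34)CC2)cn1`, has not yet been measured in this assay. It differs from compound 3 in one place: 1H-indazol-4-yl in place of pyridin-3-yl on an aromatic carbon. Going by the values given here, no measured step involves the entering group, so the only guidance is that swapping groups at this position has so far produced steps within the scatter. The expectation for compound 4 is therefore a small change, if any, with a 1.2-fold higher number from compound 3 to compound 4 (0.07 log units; within the scatter) as the expected step. Compound 4 is estimated at 20 mL.min-1.g-1, with a likely range from 10 mL.min-1.g-1 to 40 mL.min-1.g-1.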

Compound 4, intrinsic clearance in microsomes: 42 mL.min-1.g-1
Beside the measured number, compound 4's estimate is 2.1-fold (0.32 log units) below it; the whole stated range lies below it.
By their numbers in this assay, from the lowest: compounds 1, 3 and 2 (each within the scatter of the next); then compound 4.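

In this assay, this position proves able to change the read-out after all: 1H-indazol-4-yl brings a 2.5-fold higher number from compound 3 to compound 4 (0.39 log units; beyond the scatter), and the comparisons with the other two groups show a 2.2-fold higher number from compound 2 to compound 4 (0.34 log units; beyond the scatter) and a 2.8-fold higher number from compound 1 to compound 4 (0.45 log units; beyond the scatter). All three steps lie beyond the scatter, whereas the swaps among compound 1, compound 2 and compound 3 stayed within it, so the group at this place is not always interchangeable. No measurement shown here offers an explanation for the rise.

The change from compound 3 to compound 4 adds heavy atoms, a fused second ring and a hydrogen-bond donor all at once, so the compounds shown leave open which of these goes with the higher number. A 1-methyl-1H-indazol-4-yl group or a plain phenyl ring at this place would help to pull these features apart.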